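A few compounds are considered here, and "the series" means these few. Any claim that something is new, unique, unknown or untested is made for them only; others in the source may bear on it.

Working notes on the series. In a functional assay on SK-OV-3 cells (Homo sapiens) for inhibition, read by CCK-8 assay, with a stated time of 70 h (on this read-out higher numbers stand for weaker inhibition and lower numbers for stronger inhibition), compound 1 `c1ccc(COc2ccc(OCCOCCNC3CCCC3)cc2)cc1` gives 24800 nM, compound 2 `Clc1ccc(COc2ccc(OCCOCCNC3CCCC3)cc2)cc1` gives 7670 nM, and compound 3 `Nc1cccc(COc2ccc(OCCOCCNC3CCCC3)cc2)c1` gives 10800 nM. Compound 3 holds the second highest of these numbers, but it cannot be separated from compound 2: a 1.4-fold higher number from compound 2 to compound 3 (0.15 log units; within the scatter). It does stand clear of compound 1: a 2.3-fold lower number from compound 1 to compound 3 (0.36 log units; beyond the scatter).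

Compound 4 `CCOc1ccc(OCCOCCNC2CCCC2)cc1` follows from compound 3 by methyl in place of 3-aminophenyl on a saturated chain carbon bound to an oxygen on an aromatic ring. The nearest evidence is the pair of modest steps from hydrogen to chloro or amino on an aromatic carbon, a 3.2-fold lower number from compound 1 to compound 2 (0.51 log units; beyond the scatter) and a 2.3-fold lower number from compound 1 to compound 3 (0.36 log units; beyond the scatter). For the measured compounds named here, neither step removes the aromatic ring, so no measured step covers this change directly. A modest move towards higher numbers in this assay is expected, to around the value of compound 1 or somewhat past it. The expected change is a 2.8-fold higher number from compound 3 to compound 4 (0.44 log units; beyond the scatter). Compound 4 is estimated at 30000 nM, with an expected range of 12000 nM to 80000 nM.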

Compound 4, half-maximal inhibitory concentration: 90500 nM
The estimate for compound 4 lay 3.0-fold (0.48 log units) below the measured number; measured number outside the range, above it.
By their numbers in this assay, from the lowest: compounds 2 and 3 (each within the scatter of the next); then compound 1; then compound 4.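

In this assay, methyl in place of an aryl group on a saturated chain carbon bound to an oxygen on an aromatic ring gives a higher number in all three available comparisons: 3-aminophenyl (an 8.4-fold higher number from compound 3 to compound 4 (0.92 log units; beyond the scatter)), 4-chlorophenyl (a 12-fold higher number from compound 2 to compound 4 (1.07 log units; beyond the scatter)) and unsubstituted phenyl (a 3.6-fold higher number from compound 1 to compound 4 (0.56 log units; beyond the scatter)). The earlier compounds shown here varied only the substituents on this aryl group, whereas compound 4 shows that the aryl group itself counts at this position, even without chloro or amino. Nothing measured here explains the change.

On these data alone, whether the aromatic character of the ring matters stays open, and a cyclohexyl group at this position would test that. As far as these compounds go, it is also open whether a longer chain, such as n-butyl, would bring the number back towards those of compound 1, compound 2 and compound 3.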